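The source may hold more compounds than are shown below. What is called first, only, known or untested is meant among the compounds shown, and "the series" means these compounds.

Compound 1 `COc1ccc2[nH]c(=O)c(-c3nc4cc(F)ccc4[nH]3)cc2c1` gives > 100000 nM in a functional assay on BEL-7404 cells for cytotoxicity against BEL-7404 tumor cell line (Homo sapiens), read by MTT assay, with a stated time of 48 h (a higher number here means a weaker inhibitor, a lower number a stronger inhibitor), a limit of the assay.
Compound 2 `COc1ccc2[nH]c(=O)c(-c3nc4cc(Cl)ccc4[nH]3)cc2c1` gives > 100000 nM in this assay, also a limit.
Compound 3 `Cc1ccc2[nH]c(=O)c(-c3nc4ccccc4[nH]3)cc2c1` gives > 100000 nM in this assay, again a limit.

Compound 3 thus stands at the limit of > 100000 nM in this assay, at which 3 of the 3 values shown sit, and no numbered value separates it from the other two. Among the measured compounds shown here, the only step joining two measured compounds, a step that the two limits leave unreadable from compound 1 to compound 2, cannot be read: both of its ends are limits. Compound 4 `COc1ccc2[nH]c(=O)c(-c3nc4ccccc4[nH]3)cc2c1` differs from compound 3 by methoxy in place of methyl on an aromatic carbon. Compound 1 and compound 2 already carry a methoxy group at that place and remain at the limit, so no step beyond the scatter is expected in this assay from this change. Compound 4 is expected to stay at the limit, the estimated step being a number no higher from compound 3 to compound 4 (the limit leaves the size open). The value estimated for compound 4 is 100000 nM, ranging from 30000 nM to 300000 nM.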

Compound 4, half-maximal inhibitory concentration: > 100000 nM
Compound 4: only a limit was reported (the forecaster's own chance of this, stated with the estimate: 85%); the middle value lies on the limit itself.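

No step can be read between compound 4 and compound 1, compound 2 or compound 3, because all four compounds sit at the same limit: the limit of > 100000 nM in this assay, at which 4 of the 4 values shown sit.
The compounds shown leave open whether any change to the shared core gives a readable cytotoxic potency.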